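A few compounds are considered here, and "the series" means these few. Any claim that something is new, unique, unknown or untested is made for them only; others in the source may bear on it.

Measured compounds in a functional assay on NCI-H661 cells (Homo sapiens) for cytotoxicity, read by WST assay, with a stated time of 72 h; on this read-out lower numbers stand for stronger inhibition and higher numbers for weaker inhibition:
Compound 1 `CCN(CC)CCCOc1cc2ncnc(Nc3nc4ccc(C(=O)Nc5c(C)cccc5Cl)cc4s3)c2cc1OC` gives 11200 nM.
Compound 2 `CCN(CC)CCCOc1cc2ncnc(Nc3nc4ccc(C(=O)Nc5c(C)cc(C)cc5C)cc4s3)c2cc1OC` gives 7300 nM.

Compound 1 stands at the highest of the two numbers in this assay; its nearest neighbour is compound 2, and the step of a 1.5-fold lower number from compound 1 to compound 2 (0.19 log units; within the scatter) lies within the scatter, so the two values show no order between them.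

Compound 3 `COc1cc2c(Nc3nc4ccc(C(=O)Nc5c(C)cccc5Cl)cc4s3)ncnc2cc1OCCCN1CCC(C)CC1` has not yet been measured. It differs from compound 1 by 4-methylpiperidin-1-yl in place of diethylamino on a saturated chain carbon, three bonds along the chain from an oxygen on an aromatic ring. Within the data shown here, the only measured step, from compound 1 to compound 2, alters the group on the amide-type nitrogen and leaves the amine on the propyl chain untouched, so no measured step bears on the change that leads to compound 3. Among the measured compounds shown here, the data give no ground for a step in this assay beyond the scatter in either direction.

Compound 3 is therefore expected to sit close to compound 1, with an estimated step of a 1.1-fold lower number from compound 1 to compound 3 (0.05 log units; within the scatter). The expected value for compound 3 is 10000 nM, within a range from 4000 nM to 25000 nM.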

Compound 3, half-maximal inhibitory concentration: 7900 nM
Beside the measured number, compound 3's estimate is 1.3-fold (0.10 log units) above it; measured number inside the range.
By their numbers in this assay, from the lowest: compounds 2, 3 and 1 (each within the scatter of the next).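

In this assay, going from 3-(diethylamino)propyl to 3-(4-methylpiperidin-1-yl)propyl gives a 1.4-fold lower number from compound 1 to compound 3 (0.15 log units; within the scatter). Among these compounds, this is the first measured change at this position, and it shows that an open diethylamino group can give way to a six-membered non-aromatic ring with no step beyond the scatter, so the amine joins the group on the amide-type nitrogen as a second place where a single change has left the number within the scatter. No supporting measurement bears on this result.

The compounds shown leave open whether a morpholine, a piperazine or a carboxylic acid in place of the diethylamino group, or a shorter chain than propyl, would move the number beyond the scatter. They also leave open what 4-methylpiperidin-1-yl gives when paired with the 2,4,6-trimethylphenyl group on the amide-type nitrogen.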